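Adding a second chlorine to the core of compound 1

A few compounds are considered here, and "the series" means these few. Any claim that something is new, unique, unknown or untested is made for them only; others in the source may bear on it.

Compound 1 `ClCc1ccc(Cn2cnc3c(Cl)ncnc32)cc1` was examined in a functional assay on UACC-257 cells (Homo sapiens) for cytotoxicity, read by sulforhodamine B assay, with a stated time of 48 h (on this read-out higher numbers stand for lower toxicity in this test and lower numbers for higher toxicity in this test), where compound 1 gives 97700 nM, the highest of the three numbers. Compound 2 `ClCc1ccccc1Cn1cnc2c(Cl)ncnc21` gives 66100 nM, a number within the scatter of compound 1, while compound 3 `ClCc1cccc(Cn2cnc3c(Cl)nc(Cl)nc32)c1` gives 6450 nM, well beyond the scatter and the lowest of the three; compound 3 differs from compound 1 in two places at once, so its gap cannot be assigned to either change alone. Compound 4 `ClCc1ccc(Cn2cnc3c(Cl)nc(Cl)nc32)cc1` differs from compound 1 by chloro in place of hydrogen on an aromatic carbon. Within the data shown here, no measured pair isolates this change, but compound 3 carries the same second chloro and gives a far lower number, so a step downward beyond the scatter is expected, from compound 1 to compound 4 estimated as a 6.5-fold lower number from compound 1 to compound 4 (0.81 log units; beyond the scatter). Compound 4 is expected to give about 15000 nM in this assay, with a range from 4000 nM to 60000 nM.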

Compound 4, concentration lethal to 50% of the cells: 69200 nM
Compound 4: the middle estimate sits 4.6-fold (0.66 log units) below what was measured; measured number outside the range, above it.
By their numbers in this assay, from the lowest: compound 3; then compounds 2, 4 and 1 (each within the scatter of the next).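

Placing chloro on this aromatic carbon, between two ring nitrogen atoms, gives a 1.4-fold lower number from compound 1 to compound 4 (0.15 log units; within the scatter) in this assay and so leaves the number within the scatter on this core. Compound 3 carries the same chloro yet gives 6450 nM, while compound 4 gives 69200 nM in the same test, so this chloro alone does not bring the low number, and the two compounds differ only in where the chloromethyl group is attached. Nothing shown explains why the change has so little effect.

On these data alone, whether an amine or a methoxy group at this position would also leave the number unchanged stays open. So does whether the chloro at the other core position, the one present in all four compounds, matters.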